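From Bromine to Two Chlorines: Expected Cytotoxicity Outcome

A few compounds are considered here, and "the series" means these few. Any claim that something is new, unique, unknown or untested is made for them only; others in the source may bear on it.

Compound 2 `O=[N+]([O-])c1cc(-c2nnc(SCc3ccc(Br)cc3)n2Cc2ccccc2)cc([N+](=O)[O-])c1` carries a 4-bromobenzyl group on a sulfur. In an ADME assay on A-431 cells (Homo sapiens) for cytotoxicity, with a stated time of 48 h (on this read-out higher numbers stand for weaker inhibition and lower numbers for stronger inhibition), compound 2 gives > 30000 nM, which is a limit of the assay and not a number. Compound 1 `CCCSc1nnc(-c2cc([N+](=O)[O-])cc([N+](=O)[O-])c2)n1Cc1ccccc1`, with an ethyl on that same saturated chain carbon bound to a sulfur, gives > 30000 nM in this assay, again a limit rather than a number. The step from compound 1 to compound 2 is a step that the two limits leave unreadable from compound 1 to compound 2, so no size can be read from it; both values sit at the limit of > 30000 nM in this assay, at which 2 of the 2 values shown sit. Compound 3 `O=[N+]([O-])c1cc(-c2nnc(SCc3ccc(Cl)c(Cl)c3)n2Cc2ccccc2)cc([N+](=O)[O-])c1` differs from compound 2 by 3,4-dichlorophenyl in place of 4-bromophenyl on a saturated chain carbon bound to a sulfur. Among the compounds with values here, no measured step shows a readable change for any substitution at this position, so the expectation for compound 3 rests on compound 2 alone. Compound 3 is therefore expected to give about 40000 nM, with a range from 15000 nM to 100000 nM, most probably again reported only as a limit. The expected step is a step that the limit leaves unreadable from compound 2 to compound 3, none beyond the scatter.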

Compound 3, half-maximal inhibitory concentration: > 30000 nM
Compound 3: no number, only a limit; the forecaster's own chance of this, stated with the estimate: 85%; the middle value is on the limit's open side.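

Compound 1, compound 2 and compound 3 all end at a limit of the assay and not at a number, so no step among them can be read in this assay: the limit of > 30000 nM in this assay, at which 3 of the 3 values shown sit.

On these data alone, whether ethyl, 4-bromophenyl and 3,4-dichlorophenyl on a saturated chain carbon bound to a sulfur differ at all stays open.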